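The source may report more compounds than this note shows. Statements on the series, on what has been measured and on what is new or still open speak of the compounds shown alone.

Compound 1, `O=c1ccoc2cc(OCc3cn(Cc4cccc(F)c4)nn3)ccc12`: in a functional assay on SW480 cells (Homo sapiens) for cytotoxicity, read by MTT assay, with a stated time of 48 h (on this read-out lower numbers stand for stronger inhibition and higher numbers for weaker inhibition), compound 1 gives > 100000 nM, which is a limit of the assay, not a number.
Compound 2, `O=c1ccoc2cc(OCc3cn(Cc4ccc(Br)cc4)nn3)ccc12`: in this assay compound 2 gives 37500 nM.

Compound 2 therefore holds the only number shown in this assay; the other value shown is a limit. Among the measured compounds shown here, the single measured step runs from compound 1 to compound 2: an at least 2.6-fold lower number from compound 1 to compound 2 (0.42 log units; beyond the scatter). That step changes both the halogen and where it sits on the ring, and one of its ends is a limit, as the evidence shows: the limit of > 100000 nM in this assay, at which 1 of the 2 values shown sits.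

Compound 3, `O=c1ccoc2cc(OCc3cn(Cc4ccccc4Cl)nn3)ccc12`, differs from compound 2 by 2-chlorophenyl in place of 4-bromophenyl on a saturated chain carbon bound to an aromatic nitrogen. The measured step bears on it only loosely, since it swaps one halogen for another on the same kind of position, and its size is only a lower bound. Nothing shown separates the effect of the halogen from that of its place on the ring. Compound 3 is therefore expected to stay close to compound 2, with a step of a 1.3-fold higher number from compound 2 to compound 3 (0.12 log units; within the scatter) that need not exceed the scatter. The estimate for compound 3 in this assay is 50000 nM, within 15000 nM to 150000 nM.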

Compound 3, half-maximal inhibitory concentration: 23500 nM
The estimate for compound 3 lay 2.1-fold (0.33 log units) above the measured number; the range from low to high includes it.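

With compound 3, a second group at this place, on a saturated chain carbon bound to an aromatic nitrogen, gives a measured number. In this assay, putting 2-chlorophenyl in place of 4-bromophenyl gives a 1.6-fold lower number from compound 2 to compound 3 (0.20 log units; within the scatter), so these two compounds cannot be told apart, even though both the halogen and its place on the ring change. Set against the 3-fluorophenyl group, 2-chlorophenyl gives an at least 4.2-fold lower number from compound 1 to compound 3 (0.62 log units; beyond the scatter), which now makes two groups, 4-bromophenyl and 2-chlorophenyl, that stand apart from 3-fluorophenyl at this position. Compound 1 holds a limit and not a number, so that step gives only a lower bound on the size of the change: the limit of > 100000 nM in this assay, at which 1 of the 3 values shown sits.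

The three compounds shown still do not separate the identity of the halogen from its place on the ring, which a group such as 4-chlorophenyl could begin to do. Going by these compounds, it also remains open how an unsubstituted phenyl, a methoxyphenyl, or a phenyl ring bearing an amine or a carboxylic acid would behave at this position.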